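The compounds below may be only part of what the source reports. "The series", "measured", "known", "first", "only" and "open" are said of these compounds alone.

Measured so far:
Compound 1 `CN1CCN(CCCC(O)c2ccc(-c3ccc(N4C[C@H](Cn5ccnn5)OC4=O)cc3F)cn2)CC1` gives 41000 nM in an assay for inhibition of Amine oxidase [flavin-containing] A (Homo sapiens); on this read-out lower numbers stand for stronger inhibition and higher numbers for weaker inhibition.
Compound 2 `COCc1ccc(-c2ccc(N3C[C@H](Cn4ccnn4)OC3=O)cc2F)cn1` gives 1700 nM in this assay.

For the measured compounds named here, compound 2 holds the lowest of the two numbers so far in this assay; its nearest neighbour is compound 1, separated by the step of a 24-fold lower number from compound 1 to compound 2 (1.38 log units; beyond the scatter). Going by the values given here, that step exchanges the 1-hydroxy-4-(4-methylpiperazin-1-yl)butyl group of compound 1 for methoxymethyl, and it is the only measured step.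

Compound 3 `CC(C)(O)c1ccc(-c2ccc(N3C[C@H](Cn4ccnn4)OC3=O)cc2F)cn1` is the next entry. It differs from compound 2 by 1-hydroxy-1-methylethyl in place of methoxymethyl on an aromatic carbon. The change keeps the substituent short, in that sense resembling compound 2 rather than compound 1, while the entering group carries a hydroxyl as the group of compound 1 did. Among the compounds with values here, no measured step bears directly on this exchange; the one available step, a 24-fold lower number from compound 1 to compound 2 (1.38 log units; beyond the scatter), compares two groups that differ in far more than a hydroxyl, so it sets no expectation for the size of the present change. Compound 3 is therefore expected to stay close to compound 2 in this assay, the step of a 1.5-fold higher number from compound 2 to compound 3 (0.17 log units; within the scatter) being expected to fall within or near the scatter. The estimate for compound 3 is 2500 nM, with a range from 800 nM to 8000 nM.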

Compound 3, inhibition constant: 6000 nM
The estimate for compound 3 lay 2.4-fold (0.38 log units) below the measured number; the range from low to high includes it.
By their numbers in this assay, from the lowest: compound 2; then compound 3; then compound 1.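

In this assay, the position on an aromatic carbon next to the ring nitrogen, para to a large group, proves sensitive even to an exchange between two short groups: 1-hydroxy-1-methylethyl in place of methoxymethyl gives a 3.5-fold higher number from compound 2 to compound 3 (0.55 log units; beyond the scatter). The size of the substituent is thus not the only thing that matters here, while 1-hydroxy-1-methylethyl still compares well with the longer hydroxyl-bearing group, with a 6.8-fold lower number from compound 1 to compound 3 (0.83 log units; beyond the scatter), so a hydroxyl in the substituent does not by itself carry the number up to that of compound 1. No measurement is available that explains either step.

The exchange from methoxymethyl to 1-hydroxy-1-methylethyl adds a hydrogen-bond donor and a heavy atom at once, leaving open which of the two goes with the higher number, a question that hydroxymethyl or an isopropyl group at this position could separate. On these data alone, it also remains open how much of the high number of compound 1 belongs to the 4-methylpiperazin-1-yl amine and how much to the chain, which a plain butyl chain or a short aminomethyl group would help to divide.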